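The source may hold more compounds than are shown below. What is called first, only, known or untested is meant among the compounds shown, and "the series" means these compounds.

Of the compounds shown here, three built on one shared core have been tested in a functional assay (muscle tissue) with Cavia porcellus as the target; on this read-out higher numbers stand for an effect only at larger amounts of compound and lower numbers for an effect already at smaller amounts. Compound 1 `COC(=O)C1=C(C)N=C(C)/C(=C(\O)OC)C1c1c(Cl)cccc1Cl` gives 1.91 nM, compound 2 `COC(=O)C1=C(C)N=C(C)/C(=C(\O)OC)C1c1ccc(I)cc1` gives 22900 nM, and compound 3 `COC(=O)C1=C(C)N=C(C)/C(=C(\O)OC)C1c1cccc(Cl)c1Cl` gives 19.1 nM. Compound 3 therefore holds the second highest of the three numbers: it stands apart from compound 1 by a 10-fold higher number from compound 1 to compound 3 (1.00 log units; beyond the scatter) and from compound 2 by a 1200-fold lower number from compound 2 to compound 3 (3.08 log units; beyond the scatter). Compound 4 `COC(=O)C1=C(C)N=C(C)/C(=C(\O)OC)C1c1cccc(N)c1` is the untested neighbour of compound 3, and the change is 3-aminophenyl in place of 2,3-dichlorophenyl on a saturated ring carbon. Within the data shown here, two measured steps bear on it. Among the measured compounds shown here, the modest step of a 10-fold higher number from compound 1 to compound 3 (1.00 log units; beyond the scatter) shows that rearranging the two chlorines on the ring changes the number only moderately, whereas the large step of a 1200-fold lower number from compound 2 to compound 3 (3.08 log units; beyond the scatter) shows that a ring carrying only a single 4-iodo group gives a far weaker compound. Compound 4 keeps a single group on the ring, the 3-aminophenyl, but gives up both chlorines, so a step toward a higher number is expected, though probably smaller than the gap seen for compound 2, which gave 22900 nM. Compound 4 is therefore estimated to give about 600 nM, with a likely range from 60 nM to 6000 nM. That estimate corresponds to an expected step of a 31-fold higher number from compound 3 to compound 4 (1.50 log units; beyond the scatter).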

Compound 4, half-maximal effective concentration: 2000 nM
Estimate against measurement, compound 4: 3.3-fold (0.52 log units) below; low and high end bracket the measured number.
By their numbers in this assay, from the lowest: compound 1; then compound 3; then compound 4; then compound 2.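

In this assay, a ring bearing 3-aminophenyl on the saturated ring carbon gives up much of what the chlorinated rings achieve, with 3-aminophenyl in place of 2,3-dichlorophenyl producing a 100-fold higher number from compound 3 to compound 4 (2.02 log units; beyond the scatter) and 3-aminophenyl in place of 2,6-dichlorophenyl producing a 1000-fold higher number from compound 1 to compound 4 (3.02 log units; beyond the scatter). It also separates the two compounds with a single group on the ring, as 3-aminophenyl in place of 4-iodophenyl gives an 11-fold lower number from compound 2 to compound 4 (1.06 log units; beyond the scatter), so such compounds do not all share one number, and both still give higher numbers than the two dichlorophenyl compounds. Nothing available here explains why these steps are so large.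

Compounds 2 and 4 differ in both the group and where it sits, so these results cannot show which of the two matters more; 3-iodophenyl or 4-aminophenyl would separate them. As far as these compounds go, it also remains open whether a single chlorine, as in 3-chlorophenyl, would stay close to the dichlorophenyl compounds, and whether a larger amine, such as 3-dimethylaminophenyl, would behave like the 3-aminophenyl of compound 4.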